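A few compounds are considered here, and "the series" means these few. Any claim that something is new, unique, unknown or untested is made for them only; others in the source may bear on it.

Measured so far:
compound 1 `CS(=O)(=O)Nc1ccc2c(c1)S(=O)(=O)N=C(C1=C(O)[C@H]3CCC[C@H]3N(Cc3ccc(F)c(F)c3)C1=O)N2` — > 1 h
compound 2 `CS(=O)(=O)Nc1ccc2c(c1)S(=O)(=O)N=C(C1=C(O)C3CCCC3N(Cc3ccc(Cl)cc3)C1=O)N2` — > 1 h

In an in vitro ADME assay on microsomes from liver (Homo sapiens) for metabolic stability (a lower number here means that the compound disappears faster, a higher number that the compound lasts longer), compound 1 gives > 1 h, which is a limit of the assay and not a number. Compound 2 likewise gives > 1 h, again a limit rather than a number. Within the data shown here, both results sit at the limit of > 1 h in this assay, at which 2 of the 2 values shown sit, so no step between measured compounds can be read. Compound 3 `CS(=O)(=O)Nc1ccc2c(c1)S(=O)(=O)N=C(C1=C(O)C3CCCC3N(Cc3cccc(F)c3)C1=O)N2` differs from compound 2 by 3-fluorophenyl in place of 4-chlorophenyl on a saturated chain carbon bound to an amide-type nitrogen in a ring. Among the measured compounds shown here, with no measured step of this kind, the step that the limit leaves unreadable from compound 2 to compound 3 is expected to be none beyond the scatter. For compound 3 the expected value is 1.5 h, in the range 0.7 h to 3 h.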

Compound 3, half-life: 0.85 h
Estimate against measurement, compound 3: 1.8-fold (0.25 log units) above; the range from low to high includes it.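

In this assay compound 3 is the only compound shown with a number rather than a limit, 0.85 h. Compound 2 remains at a limit of the assay, > 1 h. On a saturated chain carbon bound to an amide-type nitrogen in a ring, 3-fluorophenyl in place of 4-chlorophenyl gives an at least 1.1-fold lower number from compound 2 to compound 3 (0.07 log units; that floor lies within the scatter), so this change cannot yet be told from the scatter.

From the compounds shown here alone, the size of the true step remains open, since one end of it is a limit. Also open, going by these compounds, is whether unsubstituted phenyl, or a phenyl ring carrying an amine or a carboxylic acid, would give a value clearly apart from that of compound 3.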